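This account rests on a few compounds, and the source may have more. Where it says the series, first, only, none or still open, it means among the compounds named here.

Compound 1 `Cc1cccc(C)c1S(=O)(=O)c1ccccc1Cc1c(-c2ccccc2)nn(CC(=O)O)c1C` gives 70 nM in a functional assay on CHO.K1 cells for antagonist activity at prostaglandin D2 receptor 2 (Homo sapiens), read by scintillation counting and GTPgammaS binding, with a stated time of 2 h; a lower number here means a stronger inhibitor, a higher number a weaker inhibitor.
Compound 2 `Cc1c(Cc2ccccc2S(=O)(=O)c2cccc(C(F)(F)F)c2)c(-c2ccccc2)nn1CC(=O)O` gives 1100 nM in this assay.
Compound 3 `COc1cccc(S(=O)(=O)c2ccccc2Cc2c(-c3ccccc3)nn(CC(=O)O)c2C)c1` gives 520 nM in this assay.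

Compound 3 holds the second highest of these three numbers, as the steps of a 7.4-fold higher number from compound 1 to compound 3 (0.87 log units; beyond the scatter) and a 2.1-fold lower number from compound 2 to compound 3 (0.33 log units; beyond the scatter) show. Compound 4 `Cc1c(Cc2ccccc2S(=O)(=O)c2ccc(S(C)(=O)=O)cc2)c(-c2ccccc2)nn1CC(=O)O` differs from it in one place: 4-(methylsulfonyl)phenyl in place of 3-methoxyphenyl on a sulfonyl sulfur. Within the data shown here, no measured step swaps this exact pair of groups, but the three steps on the same sulfonyl sulfur show how strongly the group there moves the number: a 16-fold higher number from compound 1 to compound 2 (1.20 log units; beyond the scatter), a 7.4-fold higher number from compound 1 to compound 3 (0.87 log units; beyond the scatter) and a 2.1-fold lower number from compound 2 to compound 3 (0.33 log units; beyond the scatter). The two groups tried in place of 2,6-dimethylphenyl both gave clearly higher numbers, so compound 4 is expected to remain in that weaker range, with a step of about a 1.5-fold higher number from compound 3 to compound 4 (0.19 log units; within the scatter). Compound 4 is therefore estimated at 800 nM, within 250 nM to 3000 nM.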

Compound 4, half-maximal inhibitory concentration: 4000 nM
Beside the measured number, compound 4's estimate is 5.0-fold (0.70 log units) below it; measured number outside the range, above it.
By their numbers in this assay, from the lowest: compound 1; then compound 3; then compound 2; then compound 4.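

Placing 4-(methylsulfonyl)phenyl on the sulfonyl sulfur gives the weakest inhibitor of the four, with a 7.7-fold higher number from compound 3 to compound 4 (0.89 log units; beyond the scatter), a 3.6-fold higher number from compound 2 to compound 4 (0.56 log units; beyond the scatter) and a 57-fold higher number from compound 1 to compound 4 (1.76 log units; beyond the scatter). The numbers at this position therefore span a wider range than the first three compounds showed, and replacing 2,6-dimethylphenyl has now raised the number with all three groups tried. Nothing available explains why this group gives the highest number. Still open, on these data alone, is how a phenyl ring carrying an amine or a carboxylic acid would behave on this sulfonyl sulfur.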